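Compound 1 and an Iodo-to-Nitro Exchange

The source may report more compounds than this note shows. Statements on the series, on what has been measured and on what is new or still open speak of the compounds shown alone.

Compound 1 `C/C(=N\NC(=S)Nc1ccccc1I)c1ccccn1`: 8.09 nM
Compound 2 `C/C(=N/NC(=S)Nc1ccccc1I)c1ccccn1`: 8.09 nM

In a functional assay on T98G cells (Homo sapiens) for cytotoxicity, read by MTT assay, with a stated time of 48 h (on this read-out higher numbers stand for weaker inhibition and lower numbers for stronger inhibition), compound 1 gives 8.09 nM, level with compound 2 at 8.09 nM. Among the compounds with values here, the only measured step, no change at the digits printed from compound 1 to compound 2 (within the scatter), concerns (the fact that compounds 1 and 2 differ only in the configuration as drawn), so it leaves the iodo group untouched and gives no direct guide to exchanging it. Compound 3 `C/C(=N\NC(=S)Nc1ccccc1[N+](=O)[O-])c1ccccn1` differs from compound 1 as follows: nitro in place of iodo on an aromatic carbon. It has nitro in place of iodo on an aromatic carbon, ortho to a large group. A modest weakening in this assay is expected, with wide uncertainty. The estimated step is a 1.7-fold higher number from compound 1 to compound 3 (0.24 log units; within the scatter). Compound 3 is expected at 14 nM, within a range of 3 nM to 70 nM.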

Compound 3, half-maximal inhibitory concentration: 6.61 nM
For compound 3 the middle estimate is 2.1-fold (0.33 log units) above the measured one; the measured number falls inside the stated range.
By their numbers in this assay, from the lowest: compounds 3, 1 and 2 (each within the scatter of the next).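

In this assay the exchange of iodo for nitro gives a 1.2-fold lower number from compound 1 to compound 3 (0.09 log units; within the scatter) on this aromatic carbon, ortho to a large group. Within the data shown here, this is the first measured change at this position, and it shows that three heavy atoms of nitro can stand in place of the single iodine atom without a step beyond the scatter. What is known about these compounds offers no explanation for this result.

With only iodo and nitro shown here, an amine or a carboxylic acid at this position remains an open question. So does how the nitro compound behaves with its double bond drawn Z, as in compound 2.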